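The compounds below may be only part of what the source reports. "The series", "measured", "known", "first", "only" and "open" are said of these compounds alone.

Measured compounds:
Compound 1, `O=COCC1=CS(=O)(=O)c2ccccc2C1=O`, gives 91.6% in a functional assay on the whole organism for inhibition, with Mus musculus as the target, at a dose of 10 mg/kg; on this read-out higher numbers stand for more inhibition at the one dose given (going by the name of the read-out) and lower numbers for less inhibition.
Compound 2, `CCC(=O)OCC1=CS(=O)(=O)c2ccccc2C1=O`, gives 99.5% in this assay.

For the measured compounds named here, compound 2 is one of only two compounds with a number in this assay, and its value sits within the scatter of that of compound 1: the one measured step, a number 7.9 percentage points higher from compound 1 to compound 2 (within the scatter), is ethyl in place of hydrogen on a carbonyl carbon, and it shows no effect beyond the scatter.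

Compound 3, `O=C1C(CNc2ccccc2)=CS(=O)(=O)c2ccccc21`, has not yet been measured in this assay. It differs from compound 2 by anilino in place of propanoyloxy on a saturated chain carbon bound to a double-bonded ring carbon. Going by the values given here, no measured step touches an anilino group or removes the propanoyloxy group as a whole; the single step known concerns only a small variation on the carbonyl carbon, and it cannot tell whether so different a group at the same place will keep inhibition at the level of compound 2. Both measured compounds sit high, so the number of compound 3 in this assay is expected to remain high, with some risk of a fall. The estimated step is a number 19.5 percentage points lower from compound 2 to compound 3 (beyond the scatter) for compound 3, downward but uncertain. Compound 3 is therefore expected to give about 80%, within a range from 45% to 100%.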

Compound 3, a percentage reported as inhibition, in the whole organism at one dose (the size of the read-out at that dose, not a potency): 0%
Compound 3: the middle estimate sits 80 percentage points above what was measured; measured number below the stated range.
By their numbers in this assay, from the lowest: compound 3; then compounds 1 and 2 (each within the scatter of the next).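

In this assay, the place on a saturated chain carbon bound to a double-bonded ring carbon turns out to be far from indifferent to what it carries: the change from propanoyloxy to anilino is a number 99.5 percentage points lower from compound 2 to compound 3 (beyond the scatter), and the change from formyloxy to anilino is a number 91.6 percentage points lower from compound 1 to compound 3 (beyond the scatter). Both steps are large and lie beyond the scatter, whereas the earlier step, a number 7.9 percentage points higher from compound 1 to compound 2 (within the scatter), covered only a variation on the carbonyl carbon and showed no effect beyond the scatter. The shared core is therefore not enough for inhibition at this dose, since compound 3, which keeps that core and carries anilino, gives 0%.

The compounds shown leave open which part of the exchange matters, the nitrogen link or the aromatic ring, and whether a saturated amine such as piperidine, a benzoyloxy group or a longer acyloxy chain such as butanoyloxy would keep or lose the inhibition. Nothing available here speaks to why the replacement has this outcome.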